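This account rests on a few compounds, and the source may have more. Where it says the series, first, only, none or still open, it means among the compounds named here.

Of the compounds shown here, three have been tested in a functional assay on MIA PaCa-2 cells (Homo sapiens) for cytotoxicity, read by fluorescence, with a stated time of 48 h; on this read-out lower numbers stand for an effect already at smaller amounts and higher numbers for an effect only at larger amounts of compound. Compound 1 `CC(C)=CCC/C(C)=C/CC/C(C)=C/CSC[C@H](NC(=O)CCCCCN1CCN(C)CC1)C(=O)NC1CC1` carries a cyclopropyl group on its amide nitrogen and a methylpiperazine at the end of its chain; in this assay compound 1 gives 10400 nM, the highest of the three numbers. Compound 2 `CC(C)=CCC/C(C)=C/CC/C(C)=C/CSC[C@H](NC(=O)CCCCCN1CCCC1)C(=O)NC1CCCCC1`, with a cyclohexyl amide and a pyrrolidine at the chain end, gives 5600 nM, which sits within the scatter of compound 1. Compound 3 `CC(C)=CCC/C(C)=C/CC/C(C)=C/CSC[C@H](NC(=O)CCCCCN1CCCC1)C(=O)NC1CCCCCCC1` is the cyclooctyl counterpart of compound 2; compound 3 gives 1900 nM, beyond the scatter from compound 1.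

Compound 4 `CC(C)=CCC/C(C)=C/CC/C(C)=C/CSC[C@H](NC(=O)CCCCCN1CCN(C)CC1)C(=O)NC1CCCCCCC1` has not yet been measured. It differs from compound 1 in one place: cyclooctyl in place of cyclopropyl on an amide-type nitrogen. Within the data shown here, the single measured step that bears on this is the one from compound 2 to compound 3, where a 2.9-fold lower number from compound 2 to compound 3 (0.47 log units; beyond the scatter). Among the measured compounds shown here, that step enlarged the ring by two carbons; the change from compound 1 to compound 4 enlarges it by five, and no measured pair shows a cyclopropyl against a cyclooctyl directly. On the basis of that step, a lower number for compound 4 is expected, a 4.2-fold lower number from compound 1 to compound 4 (0.62 log units; beyond the scatter), though the size is uncertain. In this assay compound 4 is estimated at 2500 nM, most likely between 1200 nM and 5500 nM.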

Compound 4, half-maximal effective concentration: 2500 nM
Estimate against measurement, compound 4: no gap at the digits printed, within the range that was stated.
By their numbers in this assay, from the lowest: compounds 3 and 4 (each within the scatter of the next); then compounds 2 and 1 (each within the scatter of the next).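

In this assay the exchange of cyclopropyl for cyclooctyl on the amide nitrogen, with the 4-methylpiperazin-1-yl chain end kept in place, gives a 4.2-fold lower number from compound 1 to compound 4 (0.62 log units; beyond the scatter) and so shows that the ring at this position also changes the number with this chain end, not only with the pyrrolidin-1-yl end of the earlier pair. With cyclooctyl held fixed, exchanging the chain end gives a 1.3-fold higher number from compound 3 to compound 4 (0.12 log units; within the scatter) and so leaves the two chain-end groups indistinguishable in this pair. No separate measurement is available to explain either step.

Only cyclopropyl, cyclohexyl and cyclooctyl appear on the amide nitrogen, so these compounds cannot tell whether the number keeps falling with a still larger ring such as cyclododecyl, or how an open-chain group such as tert-butyl or an aromatic one such as benzyl would compare. Going by these compounds, at the other end of the molecule, it remains open whether a morpholine, a simple dimethylamine or a shorter chain leading to the amine would also leave the number unchanged.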